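This account rests on a few compounds, and the source may have more. Where it says the series, first, only, none or still open, it means among the compounds named here.

Measured so far:
compound 1, `CC(C)c1cccc(NC(=O)N[C@@H](C)c2ccccc2)c1`: 95%
compound 2, `C[C@H](NC(=O)Nc1cccc(F)c1)c1ccccc1`: 97%

In an ADME assay on the whole organism with Oryza sativa as the target, tested at 0.1 uM (a higher number here means a weaker effect of the compound at the concentration tested, a lower number a stronger effect), compound 1 gives 95% and compound 2 gives 97%. Of the two numbers, that of compound 2 stands nominally higher, yet the step of a number 2 percentage points higher from compound 1 to compound 2 (within the scatter) lies within the scatter, so the two compounds cannot be separated on this read-out. Compound 3, `C[C@H](NC(=O)Nc1cccc(I)c1)c1ccccc1`, has not been measured. It differs from compound 2 as follows: iodo in place of fluoro on an aromatic carbon. Going by the values given here, no measured step exchanges one halogen for another; the only step available, a number 2 percentage points higher from compound 1 to compound 2 (within the scatter), concerns a different exchange and stayed within the scatter. Nothing in the series therefore points to a step beyond the scatter in this assay for compound 3, and the expected step of a number 2 percentage points lower from compound 2 to compound 3 (within the scatter) is accordingly small. Compound 3 is estimated at 95%, with a range from 85% to 100%.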

Compound 3, a percentage reported as activity, at one concentration (the size of the read-out at that concentration, not a potency): 98%
Compound 3: the middle estimate sits 3 percentage points below what was measured; measured number inside the range.
By their numbers in this assay, from the lowest: compounds 1, 2 and 3 (each within the scatter of the next).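

In this assay, the aromatic carbon meta to a large group has now held isopropyl, fluoro and iodo, and the read-out separates none of them. Going by these compounds alone, the first exchange of one halogen for another gives a number 1 percentage points higher from compound 2 to compound 3 (within the scatter), and replacing isopropyl with iodo gives a number 3 percentage points higher from compound 1 to compound 3 (within the scatter), so neither step adds to what the exchange of isopropyl for fluoro showed. At this position and at this single concentration, the three groups cannot be told apart, and nothing available bears on why they read alike.

Going by these compounds, whether any group at this position can produce a step beyond the scatter remains open, for instance an amine or a carboxylic acid in place of the iodo. Also open, on these data alone, is whether a change elsewhere on the shared core would matter more than one at this carbon.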